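Swapping the anilide aryl group of compound 2

The source may report more compounds than this note shows. Statements on the series, on what has been measured and on what is new or still open speak of the compounds shown alone.

Of the compounds shown here, two have been measured in a functional assay on CHO cells for antagonist activity at Orexin/Hypocretin receptor type 1 (Homo sapiens), read by FLIPR and calcium flux (on this read-out lower numbers stand for stronger inhibition and higher numbers for weaker inhibition), so far. Compound 1 `Cc1ccc(C)c(NC(=O)CSc2nnc(-c3ccoc3C)n2Cc2ccco2)c1` is reported only as a limit of the assay: in this assay compound 1 gives > 15800 nM. For the measured compounds named here, compound 2 `CC(=O)c1cccc(NC(=O)CSc2nnc(-c3ccoc3C)n2Cc2ccco2)c1` is the only compound with a number: in this assay compound 2 gives 3160 nM. On the numbers shown, compound 2 therefore stands alone, with one further value being a limit (the limit of > 15800 nM in this assay, at which 1 of the 2 values shown sits). Going by the values given here, the single measured step, an at least 5.0-fold lower number from compound 1 to compound 2 (0.69 log units; beyond the scatter), shows that the aryl group on the amide-type nitrogen matters.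

Compound 3 `Cc1occc1-c1nnc(SCC(=O)Nc2ccc(N(C)C)cc2)n1Cc1ccco1` has not yet been measured. It differs from compound 2 by 4-(dimethylamino)phenyl in place of 3-acetylphenyl on an amide-type nitrogen. The measured step from compound 1 to compound 2 bears on this change only loosely, since the acetyl group that accompanied the gain there is removed again in compound 3 and replaced by a different substituent. The expectation is therefore a step back toward weaker inhibition, of modest size, a 2.5-fold higher number from compound 2 to compound 3 (0.40 log units; beyond the scatter). In this assay compound 3 is expected to give about 8000 nM, with a range from 2500 nM to 25000 nM.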

Compound 3, inhibition constant: 794 nM
Estimate against measurement, compound 3: 10-fold (1.00 log units) above; the measured number lies below the stated range.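

In this assay, the step on the amide-type nitrogen, a 4.0-fold lower number from compound 2 to compound 3 (0.60 log units; beyond the scatter), shows that the acetyl group is not needed for activity at this position, and that the gain comes with no change in the counts of heavy atoms, hydrogen-bond donors or acceptors between 3-acetylphenyl and 4-(dimethylamino)phenyl. The aryl group here therefore has an effect that those counts do not capture, and the wider span across this position is an at least 19-fold lower number from compound 1 to compound 3 (1.29 log units; beyond the scatter). That span can be read only as a bound, since compound 1 is reported as a limit of the assay: the limit of > 15800 nM in this assay, at which 1 of the 3 values shown sits.

What the compounds leave open is whether the gain follows the dimethylamino group itself or the place it occupies on the phenyl ring, since both differ together between compound 2 and compound 3; 3-(dimethylamino)phenyl and 4-acetylphenyl groups would separate the two. Also open, going by these compounds, is how an unsubstituted phenyl, a 4-aminophenyl or a 4-carboxyphenyl group would compare on this nitrogen, and whether the gain would carry over to other changes in the shared core.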